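Dropping one methyl from compound 1

The source may hold more compounds than are shown below. What is called first, only, known or untested is meant among the compounds shown, and "the series" means these compounds.

Compound 1 `COc1cccc(Nc2nc(-n3cc(C)nc3C)cs2)c1` holds the higher of the two numbers in a functional assay on RKO cells (Homo sapiens) for cytotoxicity, read by resazurin assay, with a stated time of 72 h; a lower number here means a stronger inhibitor, a higher number a weaker inhibitor: compound 1 gives 22500 nM, while compound 2 `COc1ccc(Nc2nc(-n3c(C)nc4ccccc43)cs2)cc1` gives 25 nM, a gap well beyond the scatter. Compound 3 `COc1cccc(Nc2nc(-n3ccnc3C)cs2)c1` differs from compound 1 by hydrogen in place of methyl on an aromatic carbon, turning 2,4-dimethyl-1H-imidazol-1-yl into 2-methyl-1H-imidazol-1-yl. For the measured compounds named here, no measured pair isolates this change, so no step beyond the scatter is expected in this assay, in either direction. The expected size is a 1.1-fold lower number from compound 1 to compound 3 (0.05 log units; within the scatter). For compound 3 the estimated value is 20000 nM, with an expected range of 7000 nM to 60000 nM.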

Compound 3, half-maximal inhibitory concentration: 22500 nM
Estimate against measurement, compound 3: 1.1-fold (0.05 log units) below, and the stated range covers the measured number.
By their numbers in this assay, from the lowest: compound 2; then compounds 1 and 3 (each within the scatter of the next).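

Going from 2,4-dimethyl-1H-imidazol-1-yl to 2-methyl-1H-imidazol-1-yl gives no change at the digits printed from compound 1 to compound 3 (within the scatter) in this assay, the only single-place reading in the series so far. At this aromatic carbon, then, methyl and hydrogen cannot be told apart in this read-out, at a level of weak inhibition. Nothing on hand offers a reason for this flat step.

Open, as far as these compounds go, is whether an ethyl, a primary amine or a carboxylic acid on this same carbon would also leave the number unmoved. Also open, from the compounds shown here alone, is whether the remaining methyl group, on the same ring, can give way to hydrogen.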